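Swapping an Ether Bridge for a Direct Biaryl Link

This account rests on a few compounds, and the source may have more. Where it says the series, first, only, none or still open, it means among the compounds named here.

Measured so far, in an assay on isolated protein for inhibition of 2-Hydroxyacid oxidase 2 (Homo sapiens), tested at 1 uM; a higher number here means a stronger effect of the compound at the concentration tested, a lower number a weaker effect:
compound 1, `Cc1n[nH]c(C(N)=O)c1Cc1cccc(-c2ccc(F)cc2)c1`, gives 1%
compound 2, `Cc1n[nH]c(C(=O)O)c1Cc1ccc(Oc2ccccc2)cc1`, gives 10%
compound 3, `Cc1n[nH]c(C(=O)O)c1Cc1cccc(-c2ccc(C(N)=O)cc2)c1`, gives 18%

Among these three numbers compound 2 sits second highest. Its nearest neighbour is compound 3 and the furthest is compound 1; both of these gaps fall within the usual scatter of this assay, so the three compounds cannot be ranked against one another on the evidence shown. All three are weak at the concentration tested.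

The compound that follows, compound 4, `Cc1n[nH]c(C(=O)O)c1Cc1ccc(-c2ccc(F)cc2)cc1`, is compound 2 with a single change: 4-fluorophenyl in place of phenoxy on an aromatic carbon. Within the data shown here, no pair of measured compounds differing in only one place is available, so there is no measured step to lean on. Compound 1 carries the same 4-fluorophenyl group, on a different core, and gives 1%; compound 3 carries a biaryl on the shared core and gives 18%. Neither suggests a large move in this assay.

Compound 4 is therefore expected to stay close to compound 2, with the estimated step of a number 1 percentage points lower from compound 2 to compound 4 (within the scatter) lying within the scatter. The estimate for compound 4 is 9%, expected to fall between 0% and 25%.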

Compound 4, a percentage reported as inhibition, at one concentration (the size of the read-out at that concentration, not a potency): 11%
For compound 4 the middle estimate is 2 percentage points below the measured one, and the stated range covers the measured number.
By their numbers in this assay, from the lowest: compounds 1, 2, 4 and 3 (each within the scatter of the next, the first and the last beyond it).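

In this assay, among these compounds, this is the first reading of a change made in one place on the shared core, and it comes out as a number 1 percentage points higher from compound 2 to compound 4 (within the scatter). At this aromatic carbon, para to a large group, phenoxy and 4-fluorophenyl therefore cannot be told apart at the concentration tested, even though the exchange removes the phenoxy oxygen, brings in a fluorine and attaches the outer ring directly. Nothing measured on these compounds bears on why the two groups read alike.

The compounds shown leave open whether any group at this carbon can move the number beyond the scatter, for example an amine, a morpholine ring or a longer chain in place of the 4-fluorophenyl. They also leave open what the carboxylic acid of the shared core contributes: compound 1 differs from compound 4 in more than one place, so no single-place comparison of that acid with another group on the core is available.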